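Swapping the anilide ring partner of compound 1

The source may hold more compounds than are shown below. What is called first, only, known or untested is meant among the compounds shown, and "the series" means these compounds.

Of the compounds shown here, three sharing one core have been tested in a functional assay on HEK293 cells for agonist activity at D(4) dopamine receptor (Homo sapiens), read by FLIPR; a higher number here means a larger maximal response, a lower number a smaller maximal response. Compound 1 `O=C(CN1CCC(c2cccc[n+]2[O-])CC1)Nc1cccc(F)c1` gives 70%, the highest of the three. Compound 2 `COc1cccc(C)c1NC(=O)CN1CCC(c2cccc[n+]2[O-])CC1` gives 56% and compound 3 `CC(C)Oc1cccc(NC(=O)CN2CCC(c3cccc[n+]3[O-])CC2)c1` gives 48%. Within the data shown here, the only single-point step among them is a number 22 percentage points lower from compound 1 to compound 3 (beyond the scatter), a modest fall.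

Compound 4 `Cc1cc(Br)ccc1NC(=O)CN1CCC(c2cccc[n+]2[O-])CC1` has not yet been tested. Compared with compound 1 the change is 4-bromo-2-methylphenyl in place of 3-fluorophenyl on an amide-type nitrogen. This touches the same part of the molecule as the step from compound 1 to compound 3, where the aromatic ring on the amide-type nitrogen was altered and the maximal response fell. Compound 2, which also carries a methyl on that ring, reached a lower number than compound 1. Both observations point the same way, so a drop of modest size is expected, though the new ring is not the same as either tested one.

The estimated step is a number 15 percentage points lower from compound 1 to compound 4 (beyond the scatter), giving an expected value for compound 4 of 55%, likely between 40% and 70%.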

Compound 4, largest response reached (reported as efficacy), in percent of the reference or control that the assay uses: 61%
The estimate for compound 4 lay 6 percentage points below the measured number; low and high end bracket the measured number.
By their numbers in this assay, from the lowest: compounds 3, 2, 4 and 1 (each within the scatter of the next, the first and the last beyond it).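

In this assay, placing 4-bromo-2-methylphenyl on the amide-type nitrogen instead of 3-fluorophenyl gives a number 9 percentage points lower from compound 1 to compound 4 (within the scatter). Changes on this ring therefore do not always shift the maximal response measurably: the isopropoxy swap gave a number 22 percentage points lower from compound 1 to compound 3 (beyond the scatter), but this larger replacement of the whole ring cannot be told apart from compound 1. No measurement here explains why these two changes differ.

The effects of the bromine and the methyl remain unseparated, so 4-bromophenyl and 2-methylphenyl on the same nitrogen would each be informative. As far as these compounds go, it also remains open how the response would respond to a more different group on this ring, such as an amine or a carboxylic acid.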